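The source may report more compounds than this note shows. Statements on the series, on what has been measured and on what is new or still open speak of the compounds shown alone.

Working notes on a small set of pyrimidinone derivatives tested in an assay on membranes from CHO cells for displacement of a labelled ligand from adenosine receptor A1 (Homo sapiens), read by scintillation counting, with a stated time of 60 min, tested at 1 uM; a higher number here means more inhibition at the concentration tested (going by the name of the read-out), a lower number less inhibition.

Compound 1 `CC1=C(C(=O)CC(C)C)C(c2ccco2)NC(=O)N1` is one of two measured members. In this assay compound 1 gives 16%. Among the measured compounds shown here, compound 2 `CC(=O)C1=C(C)NC(=O)NC1c1ccsc1` differs from compound 1 in two places, so no single step connects the pair; in this assay compound 2 gives 9%. For the measured compounds named here, compound 2 stands lowest of the two numbers measured so far, but its nearest neighbour, compound 1, sits within the scatter, so no order between the two can be read from these figures. Both numbers are modest at the concentration tested.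

Compound 3 `CC1=C(C(=O)CC(C)C)C(c2ccsc2)NC(=O)N1` has not yet been measured. It is compound 2 with one change: isopropyl in place of hydrogen on a saturated chain carbon bound to a carbonyl carbon. No measured pair shows this change on its own, so the size of its effect is unknown; the figures for compound 1 and compound 2 give no reason to expect a step beyond the scatter in either direction. The step from compound 2 to compound 3 is expected to be a number 5 percentage points higher from compound 2 to compound 3 (within the scatter). In this assay compound 3 is estimated at 14%, with a range from 2% to 30%.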

Compound 3, a percentage reported as inhibition, at one concentration (the size of the read-out at that concentration, not a potency): 37%
Estimate against measurement, compound 3: 23 percentage points below; the measured number lies above the stated range.
By their numbers in this assay, from the lowest: compounds 2 and 1 (each within the scatter of the next); then compound 3.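

In this assay, isopropyl in place of hydrogen on a saturated chain carbon bound to a carbonyl carbon, with thiophen-3-yl held constant, gives a number 28 percentage points higher from compound 2 to compound 3 (beyond the scatter) and so shows that this chain position can move the read-out, which compounds 1 and 2 alone could not show. With isobutylcarbonyl held constant, thiophen-3-yl in place of furan-2-yl on a saturated ring carbon gives a number 21 percentage points higher from compound 1 to compound 3 (beyond the scatter), so the ring substituent can also move the number, and compound 3 stands clear of both other compounds. Nothing available here accounts for either step.

From the compounds shown here alone, it remains open whether a longer chain, a cyclohexyl group or an amine in place of isopropyl would raise or lower the number, and whether thiophen-3-yl in place of furan-2-yl would give a similar step with the acetyl group in place. Going by these compounds, these readings from this assay come from one concentration, so the potency of compound 3 also remains open.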